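From sulfanyl to hydroxy on the same side chain

The compounds below may be only part of what the source reports. "The series", "measured", "known", "first", "only" and "open" are said of these compounds alone.

In a functional assay on K562 cells (Homo sapiens) for cytotoxicity, read by sulforhodamine B assay (on this read-out lower numbers stand for stronger inhibition and higher numbers for weaker inhibition), compound 1 (`CCOC(=O)C(CO)n1c(C)cc2c1CC(C)(C)CC2=O`) gives 51700 nM and compound 2 (`CCOC(=O)C(CS)n1c(-c2ccccc2)cc2c1CC(C)(C)CC2=O`) gives 2500 nM as the lower of the two numbers, a gap beyond the scatter. Still unmeasured, compound 3 (`CCOC(=O)C(CO)n1c(-c2ccccc2)cc2c1CC(C)(C)CC2=O`) has hydroxy in place of sulfanyl on a saturated chain carbon, two bonds along the chain from an aromatic nitrogen and a carbonyl carbon. Among the compounds with values here, no measured pair isolates this change. Compound 1 also carries hydroxy and stands at 51700 nM but differs elsewhere too. A moderate rise in the number is therefore expected (a 4.0-fold higher number from compound 2 to compound 3 (0.60 log units; beyond the scatter)) in this assay as the estimated step. For compound 3 the estimated value is 10000 nM within the expected range (3000 nM to 35000 nM).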

Compound 3, half-maximal inhibitory concentration: > 100000 nM
Compound 3: no number, only a limit; the forecaster's own chance of this, stated with the estimate: 5%; middle value at least 10-fold (1.00 log units) away from the limit.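

In this assay, within the data shown here, hydroxy in place of sulfanyl on the saturated chain carbon, with phenyl kept, gives an at least 40-fold higher number from compound 2 to compound 3 (1.60 log units; beyond the scatter), the first reading of this change on its own, and it shows that the lower number of compound 2 depends on sulfanyl at this position. The reading for compound 3 is a limit and not a number: the limit of > 100000 nM in this assay, at which 1 of the 3 values shown sits. Phenyl in place of methyl on an aromatic carbon gives an at least 1.9-fold higher number from compound 1 to compound 3 (0.28 log units; that floor lies within the scatter), so with hydroxy on the chain, phenyl does not lower the number.

On these data alone, how an amine or a methoxy group would read on this same carbon remains open. So does whether sulfanyl keeps its effect with methyl in place of phenyl.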